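From Phenoxy to Carbamoyl: Expecting a Weaker Inhibitor

This account rests on a few compounds, and the source may have more. Where it says the series, first, only, none or still open, it means among the compounds named here.

Of the compounds shown here, three sharing one core have been measured in an assay on isolated protein for inhibition of 2-Hydroxyacid oxidase 2 (Homo sapiens), tested at 10 uM; on this read-out lower numbers stand for a weaker effect and higher numbers for a stronger effect at the one concentration tested. Compound 1 `Cc1n[nH]c(C(=O)O)c1Cc1cccc(-c2ccc(C#N)cc2)c1` gives 46%, compound 2 `Cc1n[nH]c(C(=O)O)c1Cc1ccc(Oc2ccccc2)cc1` gives 43%, and compound 3 `Cc1c(Cc2cccc(-c3ccc(F)cc3)c2)c(C(=O)O)nn1C` gives 4%. Compound 2 thus stands second highest of the three: its number lies within the scatter of that of compound 1, so the two cannot be told apart, while compound 3 sits far below both, beyond the scatter.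

Compound 4 `Cc1n[nH]c(C(=O)O)c1Cc1ccc(C(N)=O)cc1` has not yet been measured. It differs from compound 2 in one place: carbamoyl in place of phenoxy on an aromatic carbon. A group carrying its own ring gives way to a group with no ring, at the position para to a large group. For the measured compounds named here, no pair of measured compounds differs in only this way, so the size of such a step is unknown here. Because compound 2 gives 43% with the larger group in place, compound 4 is expected to inhibit less, with a step of a number 18 percentage points lower from compound 2 to compound 4 (beyond the scatter) that is expected to fall beyond the scatter. The estimate for compound 4 in this assay is 25%, expected to lie between 5% and 48%.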

Compound 4, a percentage reported as inhibition, at one concentration (the size of the read-out at that concentration, not a potency): 8%
Estimate against measurement, compound 4: 17 percentage points above; measured number inside the range.
By their numbers in this assay, from the lowest: compounds 3 and 4 (each within the scatter of the next); then compounds 2 and 1 (each within the scatter of the next).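

In this assay, putting carbamoyl in place of phenoxy on this aromatic carbon, para to a large group, comes with a number 35 percentage points lower from compound 2 to compound 4 (beyond the scatter) and counts as a large step. The position is therefore not indifferent to the group it carries, and the read-out here can fall sharply with a single change. The earlier compounds included no pair differing in only one place, so this is the first measured size of such a change, though nothing shown here accounts for it.

This one step removes a group with its own ring and brings in a smaller group with none, so it cannot separate the loss of the ring from the arrival of carbamoyl. A methoxy group or a benzyloxy group at this place would be needed to tell those two apart.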